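Replacing the Nonyl Chain: What Cytotoxicity to Expect

A few compounds are considered here, and "the series" means these few. Any claim that something is new, unique, unknown or untested is made for them only; others in the source may bear on it.

Of the compounds shown here, two have so far been tested in an ADME assay on HFF cells (Homo sapiens) for cytotoxicity, read by MTT assay, with a stated time of 72 h; a lower number here means a stronger inhibitor, a higher number a weaker inhibitor. Compound 1 `COc1ccc(-c2cn(C/C=C3\OC(=O)C(OCc4ccccc4)=C3OCc3ccccc3)nn2)cc1` reaches only the limit of the assay, giving > 100000 nM, which is a limit and not a measured number. Compound 2 `CCCCCCCCCCc1cn(C[C@H](O)[C@H]2OC(=O)C(OCc3ccccc3)=C2OCc2ccccc2)nn1` likewise returns > 100000 nM, again a limit of the assay rather than a value. Compound 2 therefore stands at the limit of > 100000 nM in this assay, at which 2 of the 2 values shown sit, and no finer placement of it is possible from the numbers shown. Compound 3 `Cc1ccc(S(=O)(=O)NCc2cn(C[C@H](O)[C@H]3OC(=O)C(OCc4ccccc4)=C3OCc3ccccc3)nn2)cc1` is the next compound, differing from compound 2 in one place: ((4-methylphenyl)sulfonyl)amino in place of nonyl on a saturated chain carbon bound to an aromatic carbon. Among the measured compounds shown here, no step between two measured compounds is on hand to gauge what this change might do in this assay, and both tested compounds sit at the same limit. The step that the limit leaves unreadable from compound 2 to compound 3 is expected to be none beyond the scatter. Compound 3 is accordingly estimated at 150000 nM, within a range from 50000 nM to 500000 nM.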

Compound 3, half-maximal inhibitory concentration: 50 nM
Beside the measured number, compound 3's estimate is 3000-fold (3.48 log units) above it, and the stated range ends above it.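

In this assay, the change from nonyl to ((4-methylphenyl)sulfonyl)amino gives an at least 2000-fold lower number from compound 2 to compound 3 (3.30 log units; beyond the scatter). The two earlier compounds shared one limit and so gave no sign that this assay responds to any structural change, whereas this step shows that the group on this saturated chain carbon bound to an aromatic carbon can decide whether a measurable number appears at all. The true size of the step remains unknown because the value of compound 2 is a limit and not a number: the limit of > 100000 nM in this assay, at which 2 of the 3 values shown sit.

The compounds shown do not tell which part of the ((4-methylphenyl)sulfonyl)amino group carries the step. On these data alone, whether a plain amine, a carboxamide or a sulfonamide without the methyl would do the same in this place also remains open.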